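Moving the iodine on a pyrimidine series against melanoma cells

A few compounds are considered here, and "the series" means these few. Any claim that something is new, unique, unknown or untested is made for them only; others in the source may bear on it.

Of the compounds shown here, three sharing one core have been tested in a functional assay on B16 cells (Mus musculus) for cytotoxicity, read by CCK-8 assay, with a stated time of 24 h; on this read-out higher numbers stand for weaker inhibition and lower numbers for stronger inhibition. Compound 1 `COc1ccccc1Oc1c(N)nc(-c2cccc(I)c2)nc1Cl` gives 27600 nM. Compound 2 `COc1ccccc1Oc1c(N)nc(-c2ccc(I)cc2)nc1Cl` gives 5400 nM. Compound 3 `COc1ccccc1Oc1c(N)nc(-c2cccc(I)c2)nc1OCCO` gives 20300 nM.

Two single changes connect these numbers. The change from compound 1 to compound 2 is 4-iodophenyl in place of 3-iodophenyl on an aromatic carbon and brought a 5.1-fold lower number from compound 1 to compound 2 (0.71 log units; beyond the scatter). The change from compound 1 to compound 3 is 2-hydroxyethoxy in place of chloro on an aromatic carbon and brought only a 1.4-fold lower number from compound 1 to compound 3 (0.13 log units; within the scatter).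

Compound 4 `COc1ccccc1Oc1c(N)nc(-c2ccc(I)cc2)nc1OCCO` has not yet been measured. It differs from compound 3 by 4-iodophenyl in place of 3-iodophenyl on an aromatic carbon. Within the data shown here, this is the same kind of change as the one from compound 1 to compound 2, but the surroundings are not identical: in compound 1 the changed group is meta to a chloro group and para to a group of 9 heavy atoms, whereas in compound 3 it is meta to a 2-hydroxyethoxy group and para to a 2-methoxyphenoxy group. Since the exchange of chloro for 2-hydroxyethoxy itself hardly moved the number, as the step of a 1.4-fold lower number from compound 1 to compound 3 (0.13 log units; within the scatter) shows, the earlier step is the best guide. Compound 4 is therefore expected to show roughly a 4.5-fold lower number from compound 3 to compound 4 (0.65 log units; beyond the scatter), beside the measured step of a 5.1-fold lower number from compound 1 to compound 2 (0.71 log units; beyond the scatter). The estimated value for compound 4 in this assay is 4500 nM, with a likely range from 1500 nM to 14000 nM.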

Compound 4, half-maximal inhibitory concentration: 19600 nM
Compound 4: the middle estimate sits 4.4-fold (0.64 log units) below what was measured; measured number outside the range, above it.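

In this assay, the move of the iodine that helped on the chloro compounds gave only a 1.0-fold lower number from compound 3 to compound 4 (0.02 log units; within the scatter), so the gain did not carry over to the core with the 2-hydroxyethoxy group: the same change on two cores in this assay, a 5.1-fold lower number (0.71 log units; beyond the scatter) from compound 1 to compound 2 and a 1.0-fold lower number (0.02 log units; within the scatter) from compound 3 to compound 4, 4.9-fold (0.69 log units) apart, beyond the scatter of two such steps. The same four compounds can be read the other way, since putting 2-hydroxyethoxy in place of chloro gave a 3.6-fold higher number from compound 2 to compound 4 (0.56 log units; beyond the scatter) once the iodine sat in the 4-iodophenyl group, unlike the small step seen with the 3-iodophenyl group: the same change on two cores in this assay, a 1.4-fold lower number (0.13 log units; within the scatter) from compound 1 to compound 3 and a 3.6-fold higher number (0.56 log units; beyond the scatter) from compound 2 to compound 4, 4.9-fold (0.69 log units) apart, beyond the scatter of two such steps. These two comparisons rest on one set of four compounds, so they are a single observation that the two changes do not act independently here, and they show neither why this happens nor whether it holds beyond these compounds.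

The compounds shown leave open whether the benefit of the 4-iodophenyl group depends on chloro itself or would also appear with another group in that place, such as bromo, methoxy or an amine. They also leave open whether a shorter or longer chain than 2-hydroxyethoxy, or a different halogen such as bromine in place of the iodine, would restore the step seen from compound 1 to compound 2.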